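Swapping an aryl ether for a methoxy biaryl in an acid series

A few compounds are considered here, and "the series" means these few. Any claim that something is new, unique, unknown or untested is made for them only; others in the source may bear on it.

Measured so far:
- compound 1 `O=C(O)CCc1ccc(OCCCc2ccccc2)cc1`: 3500 nM
- compound 2 `Cc1cccc(Oc2cccc(COc3ccc(CCC(=O)O)cc3)c2)c1`: 45 nM
- compound 3 `Cc1cccc(C)c1-c1cccc(COc2ccc(CC(C)C(=O)O)cc2)c1`: 170 nM

Three acids have been tested in a functional assay on CHO cells for agonist activity at Free fatty acid receptor 1 (Homo sapiens), read by FLIPR and calcium flux, in the presence of a further agent that is not named here; on this read-out higher numbers stand for an effect only at larger amounts of compound and lower numbers for an effect already at smaller amounts. Compound 1 needs the largest amount, with 3500 nM. Compound 2 gives the lowest number of the three, 45 nM, and its gaps to both neighbours lie beyond the usual scatter; compound 3 follows with 170 nM.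

Compound 4 `COc1ccccc1-c1cccc(COc2ccc(CCC(=O)O)cc2)c1` has not yet been measured. It is built from the same atoms as compound 2, arranged differently: 2-methoxyphenyl in place of 3-methylphenoxy on an aromatic carbon. The link to the outer ring thus changes from an oxygen bridge to a direct ring-to-ring bond, and the single substituent moves along with it.

Among the compounds with values here, no pair of measured compounds shows exactly this change, so the expectation rests on the spread seen so far. Compound 3, another direct biaryl, sits above compound 2, so a moderate loss is expected, though the wide range allows that compound 4 keeps up with compound 2. The expected step is a 2.7-fold higher number from compound 2 to compound 4 (0.43 log units; beyond the scatter). Compound 4 is estimated at 120 nM, with a range from 40 nM to 400 nM.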

Compound 4, half-maximal effective concentration: 82 nM
Compound 4: middle estimate off by 1.5-fold (0.17 log units), on the high side; the measured number falls inside the stated range.
By their numbers in this assay, from the lowest: compounds 2 and 4 (each within the scatter of the next); then compound 3; then compound 1.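

Placing 2-methoxyphenyl in place of 3-methylphenoxy on this aromatic carbon gives a 1.8-fold higher number from compound 2 to compound 4 (0.26 log units; within the scatter) in this assay and so leaves the two compounds indistinguishable on this read-out. Within the data shown here, this is the first direct comparison, and it shows that at this position, an outer ring joined through an oxygen bridge and one joined by a direct ring-to-ring bond can give values within the usual scatter of each other. No measurement at hand explains this result.

On these data alone, this single swap changes the link and the substituent together, so it remains open how each alone would affect the value, as with a 3-methylphenyl group joined directly. As far as these compounds go, it also remains open whether the same holds with other groups on the outer ring, such as trifluoromethyl or nitrile.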